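A few compounds are considered here, and "the series" means these few. Any claim that something is new, unique, unknown or untested is made for them only; others in the source may bear on it.

Measured so far in an ADME assay on Caco-2 cells (Homo sapiens) for permeability, in the apical to basolateral direction; a lower number here means that the compound crosses the layer more slowly, a higher number that the compound crosses the layer faster:

Compound 1 `CCC(=O)N1CCC(CN(C2Cc3cc(C#N)ccc3N(Cc3cncn3C)C2)S(=O)(=O)c2ccccn2)CC1`: 0.5 10^-6 cm/s
Compound 2 `C=C(C)C(=O)N1CCC(CN(C2Cc3cc(C#N)ccc3N(Cc3cncn3C)C2)S(=O)(=O)c2ccccn2)CC1`: 0.5 10^-6 cm/s

On these numbers compound 2 stands level with compound 1 at the digits shown; the only measured step, no change at the digits printed from compound 1 to compound 2 (within the scatter), lay within the scatter. Compound 3 `CC(C)C(=O)N1CCC(CN(C2Cc3cc(C#N)ccc3N(Cc3cncn3C)C2)S(=O)(=O)c2ccccn2)CC1` differs from compound 2 at one place only: isopropyl in place of 1-methylethenyl on a carbonyl carbon. Going by the values given here, the single step that bears on this position is no change at the digits printed from compound 1 to compound 2 (within the scatter), which exchanged one three-carbon group on that carbonyl carbon for another without a change beyond the scatter. Among the compounds with values here, nothing else touches this place, and the two values so far sit close together at the low end of this assay. The step of no change at the digits printed from compound 2 to compound 3 (within the scatter) is therefore expected to stay within the scatter. In this assay compound 3 is expected to give 0.5 10^-6 cm/s, with a range of 0.25 10^-6 cm/s to 1 10^-6 cm/s.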

Compound 3, apparent permeability: 0.5 10^-6 cm/s
Beside the measured number, compound 3's estimate shows no gap at the digits printed, and the stated range covers the measured number.
By their numbers in this assay, from the lowest: compounds 1, 2 and 3 (each within the scatter of the next).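

In this assay, replacing 1-methylethenyl with isopropyl on the carbonyl carbon removes the double bond outside aromatic rings and gives no change at the digits printed from compound 2 to compound 3 (within the scatter), so the read-out at this position does not depend on that double bond among the compounds shown. Placing methyl in place of hydrogen on the saturated chain carbon bound to the carbonyl carbon gives no change at the digits printed from compound 1 to compound 3 (within the scatter), so this added branch likewise produces no step beyond the scatter. The data at hand offer no explanation for these flat steps.

The compounds shown leave open whether a different kind of group on this carbonyl carbon, such as an amine, a carboxylic acid or a longer chain, would move the value in this assay. They also leave open whether any change in the shared core would do so.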